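Cytotoxicity on Vero cells: from methoxy to methyl

The source may hold more compounds than are shown below. What is called first, only, known or untested is meant among the compounds shown, and "the series" means these compounds.

The series shares a core carrying a cyclohexyl group, exemplified by compound 1 `O=C(Nc1cc2nc(C3CCCCC3)[nH]c2cc1N1CCCC1)OCC(F)(F)F`, compound 3 `CCN(CC)c1cc2[nH]c(C3CCCCC3)nc2cc1NC(=O)OCC(F)(F)F` and compound 2 `COc1ccc(C(=O)Nc2cc3nc(C4CCCCC4)[nH]c3cc2N(C)C)cc1`. In an ADME assay on Vero cells (Chlorocebus sabaeus) for cytotoxicity, read by resazurin assay, with a stated time of 3 days (on this read-out higher numbers stand for weaker inhibition and lower numbers for stronger inhibition), compound 1 gives only a limit, > 100 ug/mL. Compound 3 likewise reaches only the limit of this assay, > 100 ug/mL. Compound 2 too gives a limit rather than a number, > 100 ug/mL. For the measured compounds named here, the single measured step, a step that the two limits leave unreadable from compound 1 to compound 3, cannot be read because both of its ends sit at the limit of > 100 ug/mL in this assay, at which 3 of the 3 values shown sit. Compound 4 `Cc1ccc(C(=O)Nc2cc3nc(C4CCCCC4)[nH]c3cc2N(C)C)cc1` has not yet been measured in this assay. It differs from compound 2 in one place: methyl in place of methoxy on an aromatic carbon. Going by the values given here, no measured step bears on this change, and every value shown stands at the same limit, so nothing here points to a step in either direction beyond the scatter. Compound 4 is therefore expected to show no readable step, a step that the limit leaves unreadable from compound 2 to compound 4. The expected value of compound 4 is 150 ug/mL, within a range from 60 ug/mL to 400 ug/mL, most likely reported again as a limit.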

Compound 4, half-maximal inhibitory concentration: > 100 ug/mL
Compound 4 was reported as a limit (the forecaster's own chance of this, stated with the estimate: 85%); the middle value is on the limit's open side.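

The step from compound 2 to compound 4 cannot be read in this assay, because both compounds sit at a limit: (the limit of > 100 ug/mL in this assay, at which 4 of the 4 values shown sit). The compounds shown leave open how far any of them lies past that limit, and which change on the shared core, if any, would give a measurable value.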